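Adding a Fluoro Group to the Most Potent Compound

A few compounds are considered here, and "the series" means these few. Any claim that something is new, unique, unknown or untested is made for them only; others in the source may bear on it.

So far, three compounds sharing one core have been tested in an assay on isolated protein for inhibition of alkaline phosphatase, tissue-nonspecific isozyme (Homo sapiens); on this read-out lower numbers stand for stronger inhibition and higher numbers for weaker inhibition. Compound 1 `O=C(NCCO)c1cc(-c2ccc(Cl)cc2Cl)n[nH]1` gives 44 nM, compound 2 `CC(C)(C)NC(=O)c1cc(-c2ccc(Cl)cc2Cl)n[nH]1` gives 398 nM, and compound 3 `O=C(c1cc(-c2ccc(Cl)cc2Cl)n[nH]1)N1CCCCCC1` gives 1450 nM. Compound 1 stands lowest of the three, and both of its steps to the others lie beyond the scatter: a 9.0-fold higher number from compound 1 to compound 2 (0.96 log units; beyond the scatter) and a 33-fold higher number from compound 1 to compound 3 (1.52 log units; beyond the scatter). Between the other two, a 3.6-fold higher number from compound 2 to compound 3 (0.56 log units; beyond the scatter).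

Compound 4 `O=C(NCCO)c1cc(-c2cc(F)c(Cl)cc2Cl)n[nH]1` differs from compound 1 in one place: fluoro in place of hydrogen on an aromatic carbon. All three measured steps change the group attached through the amide-type nitrogen, exchanging 2-hydroxyethyl, tert-butyl and azepan-1-yl groups, and none of them touches the six-membered aromatic ring that carries the chloro groups. They show how much the amide end matters, but they give no information about the ring position where the fluoro enters. Among the compounds with values here, with no measured step bearing on this change, only a small step in this assay is expected for compound 4, in either direction or none beyond the scatter. Compound 4 is therefore estimated at 40 nM, with a range from 15 nM to 120 nM, which would mean an expected 1.1-fold lower number from compound 1 to compound 4 (0.04 log units; within the scatter).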

Compound 4, half-maximal inhibitory concentration: 100 nM
For compound 4 the middle estimate is 2.5-fold (0.40 log units) below the measured one; low and high end bracket the measured number.
By their numbers in this assay, from the lowest: compound 1; then compound 4; then compound 2; then compound 3.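

In this assay, the aromatic carbon that lies ortho to a chloro group, para to the other chloro group and meta to a large group turns out not to be indifferent to substitution: fluoro in place of hydrogen gives a 2.3-fold higher number from compound 1 to compound 4 (0.36 log units; beyond the scatter). Within the data shown here, the earlier compounds varied only the amide end, whereas this step keeps the 2-hydroxyethyl amide of compound 1 and changes a single hydrogen, so it is the first sign that the ring carrying the chloro groups also affects the number, even with an added group of one heavy atom. Nothing measured here explains why this small exchange moves the number upward.

A single fluoro on a single carbon cannot show whether the weaker inhibition is particular to fluoro or would follow from any group placed there, a question that a methyl, a methoxy or a third chloro group on the same carbon would help to answer. Going by these compounds, it also remains open whether the same exchange would produce a step of similar size on the tert-butyl amide of compound 2 or the azepan-1-yl amide of compound 3.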